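Trifluoromethyl for Methyl: Expecting Little Change in Cytotoxicity

The source may hold more compounds than are shown below. What is called first, only, known or untested is meant among the compounds shown, and "the series" means these compounds.

The three compounds measured so far in a functional assay on A-375 cells (Homo sapiens) for cytotoxicity, read by MTT assay; a higher number here means a weaker inhibitor, a lower number a stronger inhibitor:
compound 1 `O=S(=O)(NCCNc1nccc(-c2c(-c3cccc(F)c3)nc3sccn23)n1)c1ccc(Br)cc1` gives 13500 nM
compound 2 `O=S(=O)(NCCNc1nccc(-c2c(-c3cccc(F)c3)nc3sccn23)n1)c1ccc(F)cc1` gives 9450 nM
compound 3 `Cc1ccc(S(=O)(=O)NCCNc2nccc(-c3c(-c4cccc(F)c4)nc4sccn34)n2)cc1` gives 15400 nM

All three share one core and differ only in the group on the outer benzene ring of the sulfonamide. Compound 3 holds the highest of the three numbers, yet none of the gaps is meaningful: a 1.1-fold higher number from compound 1 to compound 3 (0.06 log units; within the scatter), a 1.6-fold higher number from compound 2 to compound 3 (0.21 log units; within the scatter), and a 1.4-fold lower number from compound 1 to compound 2 (0.15 log units; within the scatter). Bromo, fluoro and methyl at that spot therefore give numbers that cannot be told apart in this assay.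

Compound 4 `O=S(=O)(NCCNc1nccc(-c2c(-c3cccc(F)c3)nc3sccn23)n1)c1ccc(C(F)(F)F)cc1` is the next member. Compared with compound 3 the change is trifluoromethyl in place of methyl on an aromatic carbon. For the measured compounds named here, no measured step tests trifluoromethyl itself, but every swap tried at this position so far, whether bromo to fluoro, bromo to methyl or fluoro to methyl, stayed inside the scatter. The expectation for compound 4 is therefore a step of a 1.1-fold lower number from compound 3 to compound 4 (0.04 log units; within the scatter), that is, nothing beyond the usual noise in either direction. Compound 4 is estimated at 14000 nM, with a likely range from 7000 nM to 28000 nM.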

Compound 4, half-maximal inhibitory concentration: 7440 nM
For compound 4 the middle estimate is 1.9-fold (0.27 log units) above the measured one; measured number inside the range.
By their numbers in this assay, from the lowest: compounds 4, 2, 1 and 3 (each within the scatter of the next, the first and the last beyond it).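

Trifluoromethyl gives the first step at this position that clears the scatter, with a 2.1-fold lower number from compound 3 to compound 4 (0.32 log units; beyond the scatter) in this assay, so the group on the outer benzene ring of the sulfonamide is not wholly without effect, although the step is modest. That step stands alone, for both a 1.3-fold lower number from compound 2 to compound 4 (0.10 log units; within the scatter) and a 1.8-fold lower number from compound 1 to compound 4 (0.26 log units; within the scatter), which leaves compound 4 distinct from compound 3 only and not from compound 1 or compound 2. Nothing available bears on why trifluoromethyl in place of methyl moves the number at all.

On these data alone, what an amine, a carboxylic acid or a longer chain would do on this ring remains open, as does whether any of these groups would give a larger step than the modest one seen here. As far as these compounds go, all four compounds also keep the same core and are compared in this one assay on one cell type, so whether the step from methyl to trifluoromethyl carries over to another core or another cell type is unknown.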